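This account rests on a few compounds, and the source may have more. Where it says the series, first, only, none or still open, it means among the compounds named here.

Compound 3, with the structure `CNc1ncnc2c1c(-c1cccs1)cn2[C@@H]1O[C@H](CO)[C@@H](O)[C@H]1O`, carries thiophen-2-yl on its core. In a functional assay on HeLa S3 cells (Homo sapiens) for antiproliferative activity, read by XTT assay, with a stated time of 72 h (a lower number here means a stronger inhibitor, a higher number a weaker inhibitor), compound 3 gives > 20000 nM, which is a limit of this assay rather than a number. Compound 2, with the structure `COc1nc(N)nc2c1c(-c1cccs1)cn2[C@@H]1O[C@H](CO)[C@@H](O)[C@H]1O`, rests on a different core; the difference between the two cores is not broken down here. In this assay compound 2 gives > 20000 nM, again a limit. Compound 1, with the structure `COc1nc(N)nc2c1c(-c1ccsc1)cn2[C@@H]1O[C@H](CO)[C@@H](O)[C@H]1O`, arises from compound 2 through (thiophen-3-yl in place of thiophen-2-yl on an aromatic carbon). In this assay compound 1 gives > 20000 nM, also a limit, so the step that the two limits leave unreadable from compound 2 to compound 1 cannot be read, since both ends sit at the limit (the limit of > 20000 nM in this assay, at which 3 of the 3 values shown sit). Compound 4, with the structure `CNc1ncnc2c1c(-c1ccsc1)cn2[C@@H]1O[C@H](CO)[C@@H](O)[C@H]1O`, arises from compound 3 through the same change, (thiophen-3-yl in place of thiophen-2-yl on an aromatic carbon). Because all measured compounds sit at the limit (the limit of > 20000 nM in this assay, at which 3 of the 3 values shown sit), compound 4 is expected to remain at that limit as well, with an estimated step that the limit leaves unreadable from compound 3 to compound 4. Compound 4 is therefore estimated at 35000 nM in this assay, within a range from 15000 nM to 100000 nM.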

Compound 4, half-maximal inhibitory concentration: > 20000 nM
Compound 4: no number, only a limit; the forecaster's own chance of this, stated with the estimate: 85%; the middle value is on the limit's open side.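

In this assay compound 4 gives > 20000 nM, a limit of the assay and not a number. Compound 3 also sits at a limit, so the step from compound 3 to compound 4 cannot be read. The compounds shown leave open how strongly any of them acts and whether thiophen-3-yl in place of thiophen-2-yl changes activity on either core: the limit of > 20000 nM in this assay, at which 4 of the 4 values shown sit.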